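The compounds below may be only part of what the source reports. "The series", "measured", "known", "first", "only" and "open" are said of these compounds alone.

Measured compounds in an assay on CHO cells for displacement of a labelled ligand from adenosine receptor A1 (Homo sapiens), read by scintillation counting, tested at 10 uM; on this read-out lower numbers stand for less inhibition and higher numbers for more inhibition at the one concentration tested (going by the name of the read-out):

- compound 1, `CC(C)(C)c1csc(N)c1C(=O)c1ccc(Cl)cc1`, 1%
- compound 2, `Cc1c(-c2ccccc2)sc(N)c1C(=O)c1ccc(Cl)cc1`, 1%
- compound 3, `CC(C)(C)Cc1c(-c2ccc(F)cc2)sc(N)c1C(=O)c1ccc(Cl)cc1`, 1%

All three measured compounds share one core and differ only in the group carried on the ring carbon that sits beside the ring sulfur. In this assay compound 3 gives 1%, which is level with compound 1 and with compound 2 at the digits reported; any gaps between the three lie within the usual scatter of this measurement, so no order among them can be stated.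

Compound 4, `CC(C)(C)Cc1c(-c2cccs2)sc(N)c1C(=O)c1ccc(Cl)cc1`, has not yet been measured in this assay. It is reached from compound 3 by one change: thiophen-2-yl in place of 4-fluorophenyl on an aromatic carbon. Going by the values given here, no measured pair in this set isolates a comparable change, so there is no step to draw on. Given that compound 1, compound 2 and compound 3 all sit at the same low reading despite carrying different groups at this position, the step of a number 1 percentage points higher from compound 3 to compound 4 (within the scatter) is expected to be none beyond the scatter. Compound 4 is therefore estimated at 2%, with a range from 0% to 12%.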

Compound 4, a percentage reported as inhibition, at one concentration (the size of the read-out at that concentration, not a potency): 1%
Beside the measured number, compound 4's estimate is 1 percentage points above it; the range from low to high includes it.
By their numbers in this assay, from the lowest: compounds 1, 2, 3 and 4 (each within the scatter of the next).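

In this assay, going by these compounds alone, the swap of thiophen-2-yl for 4-fluorophenyl on the aromatic carbon next to the ring sulfur gives no change at the digits printed from compound 3 to compound 4 (within the scatter) and is the only comparison in the set that isolates a single change. At this position, then, a five-membered aromatic ring with one sulfur and one counted hydrogen-bond acceptor reads the same as a six-membered carbon ring carrying fluorine, with the neopentyl group held constant. No supporting data bear on why the reading stays put.

With every reading this low, the compounds shown cannot tell whether this position can affect the result at all. On these data alone, it remains open whether a basic amine such as piperidine or a carboxylic acid here, or a longer chain in place of the neopentyl group, would lift the reading beyond the scatter.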